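The compounds below may be only part of what the source reports. "The series", "measured", "known", "first", "only" and "open" are said of these compounds alone.

In an ADME assay on the whole organism (plasma, Homo sapiens) for protein binding, read by LC-MS, with a stated time of 24 h (on this read-out higher numbers stand for a larger free fraction and lower numbers for a smaller free fraction), two compounds have been measured so far. Compound 1, with the structure `CCCCN(C)C(=O)OCc1c(-c2ccc(O[C@H]3CCC[C@H](C(=O)O)C3)c(C)n2)nnn1C`, gives 0.026. Compound 2, with the structure `CCCCN(C)C(=O)OCc1c(C)noc1-c1ccc(O[C@H]2CCC[C@H](C(=O)O)C2)cn1`, gives 0.007. Of these two numbers compound 2 holds the lower one, and the gap to compound 1 lies beyond the usual scatter of repeated measurements, so compound 2 has the smaller free fraction of the pair.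

Compound 3, with the structure `Cc1noc(-c2ccc(O[C@H]3CCC[C@H](C(=O)O)C3)cn2)c1COC(=O)N(C)C1CCCC1`, has not yet been measured. It differs from compound 2 in one place: cyclopentyl in place of butyl on an amide-type nitrogen. Among the measured compounds shown here, no measured pair in this set shows a change of this kind, so there is no step to lean on. The change keeps the same kind of group on the same amide-type nitrogen, and the expected step of a 1.2-fold lower number from compound 2 to compound 3 (0.07 log units; within the scatter) is small, a slight move toward a smaller free fraction, not beyond the scatter. For compound 3 the expected value is 0.006, within a range from 0.003 to 0.012.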

Compound 3, unbound fraction: 0.004
The estimate for compound 3 lay 1.5-fold (0.18 log units) above the measured number, and the stated range covers the measured number.
By their numbers in this assay, from the lowest: compounds 3 and 2 (each within the scatter of the next); then compound 1.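

In this assay, putting cyclopentyl in place of butyl on the amide-type nitrogen gives a 1.8-fold lower number from compound 2 to compound 3 (0.24 log units; within the scatter), which lies within the usual scatter of repeated measurements. Among the compounds shown here, this is the first measured change at this position, and it shows that an open chain and a five-membered ring of carbon can sit on this nitrogen without the read-out separating the two compounds. No supporting data are available to explain why these two groups read alike.

Going by these compounds, it remains open whether a group of a different kind on this nitrogen, such as an amine, a carboxylic acid or a much longer carbon chain, would move the free fraction beyond the scatter. On these data alone, it is also open whether the same swap of butyl for cyclopentyl would read alike on the core of compound 1.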